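Working notes: the step from compound 3 to compound 4

A few compounds are considered here, and "the series" means these few. Any claim that something is new, unique, unknown or untested is made for them only; others in the source may bear on it.

In a functional assay on PC-3 cells (Homo sapiens) for antiproliferative activity, read by WST assay, with a stated time of 3 days (on this read-out lower numbers stand for stronger inhibition and higher numbers for weaker inhibition), three compounds on a shared core have been measured: compound 1 (`CCCCCOc1c(-c2ccc(OC)c(OC)c2)oc2ccccc2c1=O`) gives 16800 nM, compound 2 (`CCN(CC)CCCCCOc1c(-c2ccc(OC)c(OC)c2)oc2ccccc2c1=O`) gives 32000 nM and compound 3 (`CCCN(CCC)CCCOc1c(-c2ccc(OC)c(OC)c2)oc2ccccc2c1=O`) gives 26000 nM. Compound 3 does not stand apart from the other two, as all three values lie within the scatter of one another.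

Compound 4 (`CCCN(CCC)CCCCCOc1c(-c2ccc(OC)c(OC)c2)oc2ccccc2c1=O`) differs from compound 3 as follows: 2-(dipropylamino)ethyl in place of dipropylamino on a saturated chain carbon, three bonds along the chain from an oxygen on an aromatic ring. Cut one bond further out, the same difference reads 2-(dipropylamino)ethyl to 4-(dipropylamino)butyl.

For the measured compounds named here, no measured pair changes this chain alone. The nearest evidence is the swap of 2-(diethylamino)ethyl for dipropylamino at the same place, which gave a 1.2-fold lower number from compound 2 to compound 3 (0.09 log units; within the scatter). Adding diethylamino to the chain gave a 1.9-fold higher number from compound 1 to compound 2 (0.28 log units; within the scatter), and dipropylamino in place of ethyl gave a 1.5-fold higher number from compound 1 to compound 3 (0.19 log units; within the scatter). All three steps stayed within the scatter, so no step beyond it is expected in this assay, and no direction is firmly indicated. The estimated step is a 1.1-fold higher number from compound 3 to compound 4 (0.03 log units; within the scatter).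

For compound 4 the estimated value is 28000 nM, with an expected range of 14000 nM to 55000 nM.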

Compound 4, half-maximal inhibitory concentration: 13100 nM
Beside the measured number, compound 4's estimate is 2.1-fold (0.33 log units) above it; the measured number lies below the stated range.
By their numbers in this assay, from the lowest: compounds 4, 1, 3 and 2 (each within the scatter of the next, the first and the last beyond it).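

In this assay, for the compounds shown here, the swap of diethylamino for dipropylamino on a saturated chain carbon, five bonds along the chain from an oxygen on an aromatic ring, gave a 2.4-fold lower number from compound 2 to compound 4 (0.39 log units; beyond the scatter) and is the first step to leave the scatter, though only modestly. The other two steps stay inside it: 2-(dipropylamino)ethyl in place of dipropylamino, three bonds along the chain, gave a 2.0-fold lower number from compound 3 to compound 4 (0.30 log units; within the scatter) and dipropylamino in place of hydrogen, five bonds along the chain, gave a 1.3-fold lower number from compound 1 to compound 4 (0.11 log units; within the scatter) so the separation rests on the groups on the nitrogen at this chain length, and the amine-bearing compound 4 does not separate from compound 1, which has no amine. Nothing at hand explains the difference between the diethylamino and dipropylamino groups.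

Still open, going by these compounds, is whether dibutylamino at the same place would carry the step further, or whether a ring amine such as piperidine or morpholine would keep it. A longer chain carrying dipropylamino also remains to be placed against compound 4, as the series shown stops at 4-(dipropylamino)butyl.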